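A few compounds are considered here, and "the series" means these few. Any claim that something is new, unique, unknown or untested is made for them only; others in the source may bear on it.

Two compounds of this study share one core and differ only in the group carried on a saturated chain carbon bound to an amide-type nitrogen in a ring. Compound 1, `O=C1CN(S(=O)(=O)c2cc3ccc(Cl)cc3s2)CCN1Cc1cc2c[nH]ccc-2n1`, was tested in an assay on isolated protein for binding affinity to serine protease 1 (Homo sapiens); on this read-out higher numbers stand for weaker inhibition and lower numbers for stronger inhibition. In this assay compound 1 gives > 2900 nM, which is a limit of the assay and not a number. Compound 2, `O=C1CN(S(=O)(=O)c2cc3ccc(Cl)cc3s2)CCN1Cc1cc2cnccc2o1`, gives > 2900 nM in this assay, again a limit. The step that the two limits leave unreadable from compound 1 to compound 2 therefore cannot be read, since both of its ends rest on (the limit of > 2900 nM in this assay, at which 2 of the 2 values shown sit). Going by the values given here, compound 2 thus stands at the limit, and the only other value shown sits there as well.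

Compound 3, `Nc1[nH]ccc2nc(CN3CCN(S(=O)(=O)c4cc5ccc(Cl)cc5s4)CC3=O)cc1-2`, has not yet been measured in this assay. It differs from compound 2 by a group of 10 heavy atoms (7 carbon, 3 nitrogen; one five-membered aromatic ring with 1 hetero atom, one six-membered aromatic ring with 1 hetero atom) in place of a group of 9 heavy atoms (7 carbon, 1 nitrogen, 1 oxygen; one five-membered aromatic ring with 1 hetero atom, one six-membered aromatic ring with 1 hetero atom), on a saturated chain carbon bound to an amide-type nitrogen in a ring. Among the compounds with values here, no measured step bears readably on this change, as the single measured step is hidden by the limit. The expected step that the limit leaves unreadable from compound 2 to compound 3 is therefore an estimate without support from a measured step. For compound 3 the estimated value in this assay is 3000 nM, with an expected range from 600 nM to 10000 nM, and a limit is the most likely outcome.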

Compound 3, inhibition constant in the serine protease 1 assay: > 2900 nM
Compound 3: only a limit was reported (the forecaster's own chance of this, stated with the estimate: 60%); the middle value lies beyond the limit too.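

In the serine protease 1 assay compound 3 gives > 2900 nM, which is also a limit of the assay and not a number. So in the serine protease 1 assay the steps to compound 3 from compound 1 and from compound 2 cannot be read: the limit of > 2900 nM in the serine protease 1 assay, at which 3 of the 3 values shown sit. The compounds shown leave open how strongly compound 1, compound 2 and compound 3 each bind, and whether their groups differ in this at all. In a physicochemical assay, compound 2 gives 5.8 and compound 3 gives 9.3.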